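The source may hold more compounds than are shown below. What is called first, only, known or untested is meant among the compounds shown, and "the series" means these compounds.

Measured so far:
- compound 1 `CC(=O)c1ccc(OCc2cccc(C(F)(F)F)c2)cc1`: 48.9%
- compound 2 `CC(=O)c1cccc(OCc2cccc(F)c2)c1`: 31%
- compound 3 `CC(=O)c1cccc(OCc2cccc(Br)c2)c1`: 49.1%

All three numbers come from an assay on isolated protein for inhibition of Amine oxidase [flavin-containing] A (Homo sapiens), read by Amplex Red, with a stated time of 15 min, tested at 100 uM; a lower number here means less inhibition, a higher number more inhibition at the concentration tested (going by the name of the read-out). Compound 3 and compound 1 lie within the scatter of one another, so no order between them can be read; compound 2 sits clearly lower than either. Among the compounds with values here, the one step that can be isolated runs from compound 2 to compound 3: a number 18.1 percentage points higher from compound 2 to compound 3 (beyond the scatter), bromo in place of fluoro on an aromatic carbon, a modest gain in inhibition.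

The next compound, compound 4 `CC(=O)c1cccc(OCc2cccc(C)c2)c1`, differs from compound 3 in one place: methyl in place of bromo on an aromatic carbon. Within the data shown here, no measured pair shows methyl entering at this place, so the only guide is the halogen exchange from compound 2 to compound 3, in which the larger bromo went with a higher number than fluoro. Methyl and bromo are each a single heavy atom, so a move back toward the reading of compound 2 is possible but far from certain; the expected step in this assay, a number 7.1 percentage points lower from compound 3 to compound 4 (within the scatter), is small and most likely within the scatter, if anything downward.

Compound 4 is therefore estimated at 42% in this assay, with a plausible range of 25% to 58%.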

Compound 4, a percentage reported as inhibition, at one concentration (the size of the read-out at that concentration, not a potency): 31.1%
Beside the measured number, compound 4's estimate is 10.9 percentage points above it; measured number inside the range.
By their numbers in this assay, from the lowest: compounds 2 and 4 (each within the scatter of the next); then compounds 1 and 3 (each within the scatter of the next).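

In this assay, three groups can now be compared on an aromatic carbon, meta to a large group, and a number 18 percentage points lower from compound 3 to compound 4 (beyond the scatter) shows that bromo is not matched by methyl, even though each counts as 1 heavy atom. Fluoro and methyl cannot be told apart, with a number 0.1 percentage points higher from compound 2 to compound 4 (within the scatter) leaving both clearly under bromo, so among compounds 2, 3 and 4 only bromo stands apart and the earlier halogen step alone could not have shown this. No evidence is at hand to explain why bromo differs from the other two groups at this place.

On these data alone, whether the higher reading is particular to bromo stays open, since chloro, iodo or methoxy at the same place would show if it is shared by other groups. Within the data shown here, compound 1 differs from the others in more than one place, so no step to it can be read and its trifluoromethyl group cannot be ranked against bromo, while all these readings come from one concentration and say nothing of potency.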